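Swapping the oxan-4-yl of compound 2 for 2-methylphenyl

This account rests on a few compounds, and the source may have more. Where it says the series, first, only, none or still open, it means among the compounds named here.

Compound 2 `CCC/N=C1\S/C(=C\c2ccc(O)c(Cl)c2)C(=O)N1C1CCOCC1` gives 3.7 in a physicochemical assay for lipophilicity, read by HPLC, at pH 7.4 (on this read-out higher numbers stand for higher lipophilicity and lower numbers for lower lipophilicity), the highest of the three numbers measured. Compound 1 `CCC/N=C1\S/C(=C\c2ccc(O)cn2)C(=O)N1c1ccccc1C` gives 3 and compound 3 `CCC/N=C1\S/C(=C\c2ccc(O)c(Cl)c2)C(=O)N1c1ccccc1O` gives 2.7 in this assay. Compound 4 `CCC/N=C1\S/C(=C\c2ccc(O)c(Cl)c2)C(=O)N1c1ccccc1C` differs from compound 2 in one place: 2-methylphenyl in place of oxan-4-yl on an amide-type nitrogen in a ring. For the measured compounds named here, the only measured step at this position is a number 1.00 log units lower from compound 2 to compound 3 (beyond the scatter), where the entering group carries a hydroxy; here the entering 2-methylphenyl has no hydrogen-bond donor and no acceptor, so that step does not transfer directly. Compound 1, which also carries 2-methylphenyl, differs from compound 4 in the aromatic ring as well, so only its value is informative. A rise beyond the scatter is expected, a number 0.60 log units higher from compound 2 to compound 4 (beyond the scatter). Compound 4 is therefore estimated at 4.3, with a range from 3.7 to 4.9.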

Compound 4, distribution coefficient: 3.8
For compound 4 the middle estimate is 0.50 log units above the measured one; the measured number falls inside the stated range.
By their numbers in this assay, from the lowest: compounds 3 and 1 (each within the scatter of the next); then compounds 2 and 4 (each within the scatter of the next).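

At the amide-type nitrogen in a ring, this assay does not separate 2-methylphenyl from oxan-4-yl (a number 0.10 log units higher from compound 2 to compound 4 (within the scatter)). The low number of compound 3 is now tied to one change, methyl in place of hydroxy on an aromatic carbon (a number 1.10 log units higher from compound 3 to compound 4 (beyond the scatter)). With 2-methylphenyl held in place, 3-chloro-4-hydroxyphenyl in place of 5-hydroxypyridin-2-yl also counts (a number 0.80 log units higher from compound 1 to compound 4 (beyond the scatter)), but no measurement at hand explains any of these steps.

Going by these compounds, how this assay reads for an amine or a carboxylic acid in place of the methyl of 2-methylphenyl stays open.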